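Chloro-methylphenyl swap on the triazole of a pyran-fused core

A few compounds are considered here, and "the series" means these few. Any claim that something is new, unique, unknown or untested is made for them only; others in the source may bear on it.

Compound 1 `Cc1ccccc1-n1nncc1CN1C(=O)C2(C(C#N)=C(N)Oc3c2c2nc4ccccc4nc2c2ccccc32)c2ccccc21`: > 50000 nM
Compound 2 `Cc1cccc(-n2nncc2CN2C(=O)C3(C(C#N)=C(N)Oc4c(N)cc5nc6ccccc6nc5c43)c3ccccc32)c1`: 12300 nM

Compound 1 gives only a limit in a functional assay on A549 cells (Homo sapiens) for antiproliferative activity, read by MTT assay, with a stated time of 48 h (a higher number here means a weaker inhibitor, a lower number a stronger inhibitor), (the limit of > 50000 nM in this assay, at which 1 of the 2 values shown sits). Compound 2 gives 12300 nM, the only number shown. Compound 3 `Cc1ccc(-n2nncc2CN2C(=O)C3(C(C#N)=C(N)Oc4c(N)cc5nc6ccccc6nc5c43)c3ccccc32)cc1Cl` carries the change (3-chloro-4-methylphenyl in place of 3-methylphenyl on an aromatic nitrogen). For the measured compounds named here, no measured step involves this change, so the size is open; a step from compound 2 to compound 3 of about a 1.2-fold lower number from compound 2 to compound 3 (0.09 log units; within the scatter) is expected, no larger than the scatter in either direction. Compound 3 is estimated at 10000 nM, between 3000 nM and 40000 nM.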

Compound 3, half-maximal inhibitory concentration: 11800 nM
Beside the measured number, compound 3's estimate is 1.2-fold (0.07 log units) below it; the range from low to high includes it.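

Swapping 3-methylphenyl for 3-chloro-4-methylphenyl on an aromatic nitrogen gives a 1.0-fold lower number from compound 2 to compound 3 (0.02 log units; within the scatter) in this assay, the first step that can be read here. This position therefore accepts a chlorine and a shifted methyl together with no change beyond the scatter, although the two changes cannot be separated. No measurement shown gives a reason for this flat result.

As far as these compounds go, whether chlorine alone or the moved methyl alone would do the same remains open. So does the effect of an amine or a carboxylic acid on this phenyl ring.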